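The compounds below may be only part of what the source reports. "The series", "measured", "known", "first", "only" and "open" are said of these compounds alone.

Working notes on the series. Compound 1 `CC(C)=CCC/C(C)=C/COc1cc(=O)n(CCCO)c2c1CC(CC=C(C)C)C(C)(C)C2` carries the 3,7-dimethylocta-2,6-dien-1-yl group on an oxygen on an aromatic ring; in a functional assay on PANC-1 cells (Homo sapiens) for inhibition, read by MTT assay, with a stated time of 24 h, tested at 10 uM (a higher number here means more inhibition at the concentration tested (going by the name of the read-out), a lower number less inhibition), compound 1 gives 18.4%. Compound 2 `COc1ccc(NC(=O)Oc2cc(=O)n(CCCO)c3c2CC(CC=C(C)C)C(C)(C)C3)cc1` has (4-methoxyphenyl)carbamoyl in place of that group, and in this assay compound 2 gives 0%, the lowest of the two numbers in hand. Going by the values given here, the only measured step, a number 18.4 percentage points lower from compound 1 to compound 2 (beyond the scatter), runs downward and is the sole reference point. Compound 3 `CC(C)=CCC1Cc2c(OC(=O)Nc3ccc(F)cc3F)cc(=O)n(CCCO)c2CC1(C)C` differs from compound 2 by 2,4-difluorophenyl in place of 4-methoxyphenyl on an amide-type nitrogen. Among the compounds with values here, no measured step touches the group on the amide-type nitrogen, so nothing measured speaks for a shift in this assay beyond the scatter; compound 2 already sits at the floor of the read-out, so any move can only be upward or nil. The step in this assay is therefore expected to be a number 5 percentage points higher from compound 2 to compound 3 (within the scatter). For compound 3 the estimate in this assay is 5%, with a range from 0% to 20%.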

Compound 3, a percentage reported as inhibition, at one concentration (the size of the read-out at that concentration, not a potency): 0%
For compound 3 the middle estimate is 5 percentage points above the measured one, and the stated range covers the measured number.
By their numbers in this assay, from the lowest: compounds 2 and 3 (each within the scatter of the next); then compound 1.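

In this assay the exchange on the amide-type nitrogen gives no change at the digits printed from compound 2 to compound 3 (within the scatter) and so does not separate 2,4-difluorophenyl from 4-methoxyphenyl; with both compounds at the floor of the read-out, any difference between these groups would stay hidden. The second comparison, a number 18.4 percentage points lower from compound 1 to compound 3 (beyond the scatter) on replacing the 3,7-dimethylocta-2,6-dien-1-yl group, shows that the low number seen with the carbamoyl link is not confined to the 4-methoxyphenyl member. No evidence on the reason for these numbers is at hand.

Still open, going by these compounds, is whether a carbamoyl carrying a benzyl group or a plain alkyl chain in place of the phenyl ring would rise above the floor. Also open, on these data alone, is whether a shorter ether, such as 3-methylbut-2-en-1-yl on the same oxygen, would keep the inhibition seen with compound 1.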